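The source may hold more compounds than are shown below. What is called first, only, known or untested is meant among the compounds shown, and "the series" means these compounds.

Of the compounds shown here, two of a shared core have been measured. Compound 1 `CN(C)c1ccc2oc(-c3cc(-c4cnn(C5CCNCC5)c4)cnc3N)nc2c1` gives 1760 nM in an assay on isolated protein for inhibition of G protein-coupled receptor kinase 5 (Homo sapiens), read by TR-FRET, with stated times of 10 min and 1 h; on this read-out lower numbers stand for stronger inhibition and higher numbers for weaker inhibition. Compound 2 `Nc1ncc(-c2cnn(C3CCNCC3)c2)cc1-c1nc2ccc(-c3cn[nH]c3)cc2o1` gives 1780 nM in this assay; of the two numbers this is the higher one, but compound 1 sits so close that the two values fall within the usual scatter of repeated measurements, so no real difference between them can be claimed.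

Compound 3 `Nc1ncc(-c2cnn(C3CCNCC3)c2)cc1-c1nc2ccc(Oc3ccccc3)cc2o1` is not yet measured. It differs from compound 2 in one place: phenoxy in place of 1H-pyrazol-4-yl on an aromatic carbon. For the measured compounds named here, no pair of measured compounds shows the effect of such a change, so the size of the step is uncertain. A modest weakening seems plausible, yet a result within the scatter would not surprise. The expected step of a 1.6-fold higher number from compound 2 to compound 3 (0.20 log units; within the scatter) reflects this. Compound 3 is therefore estimated at 2800 nM in this assay, with a likely range from 900 nM to 9000 nM.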

Compound 3, half-maximal inhibitory concentration: 4000 nM
Compound 3: middle estimate off by 1.4-fold (0.15 log units), on the low side; the measured number falls inside the stated range.
By their numbers in this assay, from the lowest: compounds 1 and 2 (each within the scatter of the next); then compound 3.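

In this assay, for the compounds shown here, the change from 1H-pyrazol-4-yl to phenoxy on this aromatic carbon gives a 2.2-fold higher number from compound 2 to compound 3 (0.35 log units; beyond the scatter) and is the first step to lie beyond the scatter. This position therefore does not treat every group alike, although the weakening is modest. Nothing available gives a reason for this step.

The swap changes the ring type, the heavy-atom count and the hydrogen-bond donor count all at once, so the compounds shown cannot tell which of these differences matters. As far as these compounds go, a phenyl ring joined directly to this carbon or a pyridine ring would help to separate these differences, and whether any group here can give a clearly lower number than compound 2 remains open.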